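A Second Fluoro on the Aroyl Ring of Compound 1

The source may hold more compounds than are shown below. What is called first, only, known or untested is meant among the compounds shown, and "the series" means these compounds.

Compound 1: `CN(C(=O)NC(=O)c1ccccc1F)c1nc(C(F)(F)F)c(C(=O)N/N=C/c2ccc(C(F)(F)F)cc2)s1`, 3.97 ug/mL
Compound 2: `CN(C(=O)NC(=O)c1ccccc1F)c1nc(C(F)(F)F)c(C(=O)N/N=C/c2ccccc2C(F)(F)F)s1`, 10.1 ug/mL
Compound 3: `CN(C(=O)NC(=O)c1ccc(Cl)c(Cl)c1)c1nc(C(F)(F)F)c(C(=O)N/N=C/c2cccc([N+](=O)[O-])c2)s1`, 6.56 ug/mL

In a functional assay on HeLa cells (Homo sapiens) for inhibition, read by MTT assay, with a stated time of 72 h (a higher number here means a weaker inhibitor, a lower number a stronger inhibitor), compound 1 gives 3.97 ug/mL, the lowest of the three numbers. Compound 3 gives 6.56 ug/mL, which lies within the scatter of the number for compound 1, so no order between these two is claimed. For the measured compounds named here, the only step between measured compounds, a 2.5-fold higher number from compound 1 to compound 2 (0.41 log units; beyond the scatter), is beyond the scatter and concerns the group on the carbon with a double bond to nitrogen.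

Compound 4 `CN(C(=O)NC(=O)c1c(F)cccc1F)c1nc(C(F)(F)F)c(C(=O)N/N=C/c2ccc(C(F)(F)F)cc2)s1` differs from compound 1 by fluoro in place of hydrogen on an aromatic carbon. This change sits on the (2-fluorophenyl)carbonyl group, far from the place where compound 1 and compound 2 differ, so the step of a 2.5-fold higher number from compound 1 to compound 2 (0.41 log units; beyond the scatter) does not bear on it. Going by the values given here, no measured pair shows fluoro in place of hydrogen on that ring. Compound 4 is therefore expected to remain close to compound 1, with a 1.1-fold higher number from compound 1 to compound 4 (0.02 log units; within the scatter) expected to stay within the scatter in this assay. The estimate for compound 4 is 4.2 ug/mL, with a range from 2 ug/mL to 9 ug/mL.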

Compound 4, half-maximal inhibitory concentration: 30.6 ug/mL
The estimate for compound 4 lay 7.3-fold (0.86 log units) below the measured number, and the stated range ends below it.
By their numbers in this assay, from the lowest: compounds 1, 3 and 2 (each within the scatter of the next, the first and the last beyond it); then compound 4.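

For the compounds shown here, the change from (2-fluorophenyl)carbonyl to (2,6-difluorophenyl)carbonyl gives the first measured step on this part of the molecule: in this assay, it produces a 7.7-fold higher number from compound 1 to compound 4 (0.89 log units; beyond the scatter). The earlier step concerned only the group on the carbon with a double bond to nitrogen, whereas this one shows that a single fluoro in place of hydrogen, ortho to a large group and meta to a fluoro group, is enough to give a weaker inhibitor. Nothing available here accounts for the size of this step.

With only fluoro shown at this carbon, it remains open whether the weakening is specific to fluoro or would also appear with a methyl, a methoxy or an amine there. Going by these compounds, it is also open whether the step would hold with the 2-(trifluoromethyl)phenyl group of compound 2 in place of 4-(trifluoromethyl)phenyl.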